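This account rests on a few compounds, and the source may have more. Where it says the series, first, only, none or still open, it means among the compounds named here.

Measured compounds in an assay on striatum for inhibition of 5-hydroxytryptamine receptor 4 (Cavia porcellus), read by radioligand binding; on this read-out higher numbers stand for weaker inhibition and lower numbers for stronger inhibition:
- compound 1 `COc1cc(N)c(Cl)cc1C(=O)NC1CCN(CC2CCN(CCCCN)CC2)CC1`; compound 1 gives 6.47 nM
- compound 2 `CCCC(N)C(=O)N1CCC(CN2CCC(NC(=O)c3cc(Cl)c(N)cc3OC)CC2)CC1`; compound 2 gives 2.57 nM
- compound 3 `COc1cc(N)c(Cl)cc1C(=O)NC1CCN(CC2CCN(C(=O)CCCCN)CC2)CC1`; compound 3 gives 3.91 nM

Compound 3 stands second highest of the three numbers; its neighbours lie close, with a 1.5-fold higher number from compound 2 to compound 3 (0.18 log units; within the scatter) and a 1.7-fold lower number from compound 1 to compound 3 (0.22 log units; within the scatter) both within the scatter. The next compound, compound 4 `COc1cc(N)c(Cl)cc1C(=O)NC1CCN(CC2CCN(CC(O)CN)CC2)CC1`, carries 3-amino-2-hydroxypropyl in place of (4-aminobutyl)carbonyl on an amine nitrogen in a ring. Going by the values given here, the steps that bear on this are the two earlier changes at the same ring nitrogen: a 1.7-fold lower number from compound 1 to compound 3 (0.22 log units; within the scatter) and a 2.5-fold lower number from compound 1 to compound 2 (0.40 log units; beyond the scatter). Both swaps of the side chain on this nitrogen moved the number little, so for compound 4 a step of a 1.3-fold higher number from compound 3 to compound 4 (0.11 log units; within the scatter) in this assay is expected, not beyond the scatter. Compound 4 is therefore estimated at 5 nM, in the range 2.5 nM to 10 nM.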

Compound 4, half-maximal inhibitory concentration: 14.4 nM
Compound 4: middle estimate off by 2.9-fold (0.46 log units), on the low side, outside the stated range (above it).
By their numbers in this assay, from the lowest: compounds 2, 3 and 1 (each within the scatter of the next, the first and the last beyond it); then compound 4.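

In this assay, the ring nitrogen proves sensitive to its side chain: 3-amino-2-hydroxypropyl gives a 3.7-fold higher number from compound 3 to compound 4 (0.57 log units; beyond the scatter), a 5.6-fold higher number from compound 2 to compound 4 (0.75 log units; beyond the scatter) and a 2.2-fold higher number from compound 1 to compound 4 (0.35 log units; beyond the scatter), making compound 4 the weakest of the four. Going by these compounds alone, the earlier changes at this nitrogen gave no step of this size. No measured evidence here accounts for the loss.

The compounds shown leave open whether the step follows the hydroxyl or the shorter chain, as compound 4 differs from compound 1 in both. A plain 3-aminopropyl chain on this nitrogen would separate the two.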